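The source may hold more compounds than are shown below. What is called first, only, known or untested is meant among the compounds shown, and "the series" means these compounds.

In a functional assay on MCF7 cells (Homo sapiens) for cytotoxicity, read by MTT assay, with a stated time of 72 h (on this read-out lower numbers stand for stronger inhibition and higher numbers for weaker inhibition), compound 1 `CCCCCCCCNc1nc(SCc2ccc(C(F)(F)F)cc2)nc2ccccc12` gives 26100 nM. Compound 3 `FC(F)(F)c1ccc(CSc2nc(Nc3cccc(Cl)c3)c3ccccc3n2)cc1` gives 25100 nM, and the step of a 1.0-fold lower number from compound 1 to compound 3 (0.02 log units; within the scatter) leaves the two at the same level, so compound 1 sits beside compound 3 among the numbers that are known. Compound 2 `FC(F)(F)c1ccc(CSc2nc(Nc3ccccc3C(F)(F)F)c3ccccc3n2)cc1` reaches only a limit, > 50000 nM. The step of an at least 1.9-fold higher number from compound 1 to compound 2 (0.28 log units; that floor lies within the scatter) and the step of an at least 1.9-fold lower number from compound 2 to compound 3 (0.29 log units; that floor lies within the scatter) both rest on that limit (the limit of > 50000 nM in this assay, at which 1 of the 3 values shown sits). Compound 4 `FC(F)(F)c1ccc(CSc2nc(Nc3cccc(Br)c3)c3ccccc3n2)cc1` differs from compound 1 by 3-bromophenyl in place of octyl on a nitrogen on an aromatic ring. Going by the values given here, the closest precedent is the change to compound 3, where 3-chlorophenyl replaced octyl without moving the number beyond the scatter, and 3-bromophenyl is expected to behave alike, so the expected step is a 1.0-fold lower number from compound 1 to compound 4 (0.02 log units; within the scatter). Compound 4 is therefore estimated at 25000 nM, with a range from 10000 nM to 50000 nM.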

Compound 4, half-maximal inhibitory concentration: 25600 nM
Estimate against measurement, compound 4: 1.0-fold (0.01 log units) below; measured number inside the range.
By their numbers in this assay, from the lowest: compounds 3, 4 and 1 (each within the scatter of the next). At a limit, above all of these: compound 2.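

In this assay, bromo in place of chloro on an aromatic carbon gives a 1.0-fold higher number from compound 3 to compound 4 (0.01 log units; within the scatter) and so leaves the two halogens level. A second 3-halophenyl group, with a 1.0-fold lower number from compound 1 to compound 4 (0.01 log units; within the scatter), also stands level with the octyl chain on this nitrogen. Compound 2 remains a limit, so an at least 1.9-fold lower number from compound 2 to compound 4 (0.29 log units; that floor lies within the scatter) is only a floor: the limit of > 50000 nM in this assay, at which 1 of the 4 values shown sits. The compounds shown leave open whether an amine or a carboxylic acid on this phenyl ring, or a chain shorter than octyl on this nitrogen, would move the number beyond the scatter.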